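Hydroxy for Methoxy on the Imine Aryl: Compound 2 to Compound 3

The compounds below may be only part of what the source reports. "The series", "measured", "known", "first", "only" and "open" are said of these compounds alone.

Compound 2 `COc1ccc(N=C2NC(=O)/C(=C\c3ccc(N(C)C)cc3)S2)cc1` shares its core with compound 1 `Cc1ccccc1/N=C1\NC(=O)/C(=C\c2ccc(N(C)C)cc2)S1` and differs from it in the aryl group on the imine nitrogen. In an ADME assay on cells (Homo sapiens) for antiproliferative activity (on this read-out lower numbers stand for stronger inhibition and higher numbers for weaker inhibition), compound 1 gives only a limit of the assay, > 100000 nM. In this assay compound 2 likewise gives only a limit, > 100000 nM. Going by the values given here, both values sit at the limit of > 100000 nM in this assay, at which 2 of the 2 values shown sit, so compound 2 stands level with the one other compound measured here, and neither shows measurable inhibition.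

Compound 3 `CN(C)c1ccc(/C=C2/SC(=Nc3ccc(O)cc3)NC2=O)cc1` differs from compound 2 by hydrogen in place of methyl on an oxygen on an aromatic ring, that is, methoxy to hydroxy, 4-methoxyphenyl to 4-hydroxyphenyl. Among the compounds with values here, no step between measured compounds is available. Since compound 2 sits at the limit > 100000 nM, no shift beyond the usual scatter is expected from this change, and compound 3 is expected most likely to return a limit as well. The expected step is a number no higher from compound 2 to compound 3 (the limit leaves the size open). The estimate for compound 3 in this assay is 100000 nM, between 30000 nM and 300000 nM.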

Compound 3, half-maximal inhibitory concentration: > 100000 nM
Compound 3: a limit, no number; the forecaster's own chance of this, stated with the estimate: 85%; the middle value lies on the limit itself.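

In this assay compound 3 gives > 100000 nM, a limit of the assay and not a number. Compound 2 also gives a limit, so the step between compound 2 and compound 3 cannot be read. The compounds shown leave open what changes on the shared core would give a readable value.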